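A Second Chlorine on the Biaryl Hydrazone

The compounds below may be only part of what the source reports. "The series", "measured", "known", "first", "only" and "open" are said of these compounds alone.

Measured compounds:
- Compound 1, `Clc1ccccc1-c1ccccc1/C=N/Nc1c(Cl)cncc1Cl`, gives 174 nM
- Compound 2, `Cc1ccccc1-c1ccncc1C(=O)N(C)Cc1cc(C(F)(F)F)cc(C(F)(F)F)c1`, gives 8.5 nM
- Compound 3, `Cc1ccccc1-c1cnc(N2CCN(C)CC2)cc1N(C)C(=O)C(C)(C)c1cc(C(F)(F)F)cc(C(F)(F)F)c1`, gives 1.7 nM

All three numbers come from an assay on CHO cells for displacement of a labelled ligand from Substance-P receptor (Homo sapiens); on this read-out lower numbers stand for stronger inhibition and higher numbers for weaker inhibition. Among them, compound 1 stands at the top, which on this read-out means the weakest binding of the three: compound 2 sits a good deal lower, and compound 3 lower still, with both gaps well beyond the scatter of repeated measurements. Compounds 2 and 3 share little with compound 1 in structure beyond the general shape, so they are better seen as a backdrop than as a guide to small changes within the hydrazone of compound 1.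

Compound 4, `Clc1cncc(Cl)c1N/N=C/c1ccccc1-c1c(Cl)cccc1Cl`, has not been measured yet. It differs from compound 1 in one spot: chloro in place of hydrogen on an aromatic carbon. Nothing measured here tells how such a change plays out in this series, and a single added chlorine on a ring that already carries one is, in many series, a small step either way. The expectation is therefore a step from compound 1 to compound 4 of a 1.5-fold lower number from compound 1 to compound 4 (0.16 log units; within the scatter), most likely not clearly beyond the scatter, with a slight lean toward a lower number. Compound 4 is expected to give about 120 nM, within a range from 40 nM to 400 nM.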

Compound 4, inhibition constant: 93 nM
Beside the measured number, compound 4's estimate is 1.3-fold (0.11 log units) above it, within the range that was stated.
By their numbers in this assay, from the lowest: compound 3; then compound 2; then compounds 4 and 1 (each within the scatter of the next).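

In this assay, the change from 2-chlorophenyl to 2,6-dichlorophenyl gives a 1.9-fold lower number from compound 1 to compound 4 (0.27 log units; within the scatter), so this pair cannot be told apart on this read-out. Going by these compounds alone, this is the first direct comparison in the set. Compounds 2 and 3 differ from the hydrazone in many places and could not show the effect of a change at any single position. It shows that this aromatic carbon, ortho to a large group, can carry a chloro group in place of hydrogen without a change in binding that exceeds the usual spread of repeat measurements, although this single pair says nothing about how the series behaves more widely. No measurement shown here offers an explanation for this result.

Open, on these data alone, is whether a different group at this same position, such as fluoro, methoxy, an amine or a carboxylic acid, would move the number clearly beyond the scatter or leave it just as flat. Also open, as far as these compounds go, is whether the same chloro group would give a similarly small step on the other compounds, whose structures differ too much from compound 1 to offer any hint.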